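A few compounds are considered here, and "the series" means these few. Any claim that something is new, unique, unknown or untested is made for them only; others in the source may bear on it.

Compound 1 `Nc1nc(N)c(-c2ccc(NCc3ccnc(Cl)c3)cc2)c(COCc2ccccc2)n1`: in a functional assay on CHOK cells for antagonist activity at growth hormone secretagogue receptor type 1 (Homo sapiens), read by calcium flux (on this read-out higher numbers stand for weaker inhibition and lower numbers for stronger inhibition), compound 1 gives 3.6 nM.
Compound 2 `N#Cc1ccc(CNc2ccc(-c3c(N)nc(N)nc3COCc3ccccc3)cc2)cc1`: in this assay compound 2 gives 19 nM.

For the measured compounds named here, compound 2 stands at the higher of the two numbers measured in this assay, with compound 1 its only neighbour; the step of a 5.3-fold higher number from compound 1 to compound 2 (0.72 log units; beyond the scatter) lies beyond the scatter. Compound 3 `Nc1nc(N)c(-c2ccc(NCc3csc(Cl)c3)cc2)c(COCc2ccccc2)n1` differs from compound 2 in one place: 5-chlorothiophen-3-yl in place of 4-cyanophenyl on a saturated chain carbon bound to a nitrogen on an aromatic ring. Going by the values given here, the single measured step that bears on this change is a 5.3-fold higher number from compound 1 to compound 2 (0.72 log units; beyond the scatter), in which a 2-chloropyridin-4-yl group on the saturated chain carbon bound to a nitrogen on an aromatic ring gave the lower number and 4-cyanophenyl the higher. Since 5-chlorothiophen-3-yl, like 2-chloropyridin-4-yl, is a chlorine-carrying aromatic ring with one hetero atom, compound 3 is expected to move back toward the number of compound 1, although one step is a thin basis. For compound 3 the expected step is a 3.2-fold lower number from compound 2 to compound 3 (0.50 log units; beyond the scatter). Compound 3 is therefore estimated at 6 nM in this assay, within a range from 2 nM to 20 nM.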

Compound 3, half-maximal inhibitory concentration: 170 nM
For compound 3 the middle estimate is 28-fold (1.45 log units) below the measured one; the measured number lies above the stated range.
By their numbers in this assay, from the lowest: compound 1; then compound 2; then compound 3.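

In this assay, 5-chlorothiophen-3-yl gives the highest of the three numbers at this position, on a saturated chain carbon bound to a nitrogen on an aromatic ring, with an 8.9-fold higher number from compound 2 to compound 3 (0.95 log units; beyond the scatter) and a 47-fold higher number from compound 1 to compound 3 (1.67 log units; beyond the scatter). A chlorine-carrying aromatic ring with one hetero atom therefore does not by itself give a low number here: 2-chloropyridin-4-yl and 5-chlorothiophen-3-yl both fit that description, yet they stand at opposite ends of the series, and 4-cyanophenyl, which carries no chlorine, falls between them. Nothing measured here accounts for this order.

The compounds shown leave open whether the chlorine contributes at all in either heteroaromatic group, as the unchlorinated pyridin-4-yl and thiophen-3-yl groups do not appear among them. They also leave open how a 2-methylpyridin-4-yl group or a saturated piperidin-4-yl ring would read at this position.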